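Notes on the step from compound 3 to compound 4

A few compounds are considered here, and "the series" means these few. Any claim that something is new, unique, unknown or untested is made for them only; others in the source may bear on it.

Within the data shown here, compound 3 `CC1(N)CCN(c2ncnc3[nH]cc(-c4cccc(Cl)c4)c23)CC1` gives 278 nM in an assay for inhibition of serine/threonine-protein kinase 3 (Homo sapiens), read by luminescence and ADP-Glo, in the presence of a further agent that is not named here (on this read-out lower numbers stand for stronger inhibition and higher numbers for weaker inhibition), the second highest of the three numbers measured so far. Compound 2 `CNC1CCN(c2ncnc3[nH]cc(-c4cccc(Cl)c4)c23)CC1` gives 293 nM and compound 1 `CCCN(C)c1ncnc2[nH]cc(-c3cccc(Cl)c3)c12` gives 218 nM; all three lie within the scatter of one another, as the steps of a 1.3-fold higher number from compound 1 to compound 2 (0.13 log units; within the scatter), a 1.3-fold higher number from compound 1 to compound 3 (0.11 log units; within the scatter) and a 1.1-fold lower number from compound 2 to compound 3 (0.02 log units; within the scatter) show. Compound 4 `Clc1cccc(-c2c[nH]c3ncnc(N4CCCCC4)c23)c1` has not been measured. It differs from compound 3 in one place: piperidin-1-yl in place of 4-amino-4-methylpiperidin-1-yl on an aromatic carbon. The most closely related measured step also alters the substitution on the piperidine ring and is a 1.1-fold lower number from compound 2 to compound 3 (0.02 log units; within the scatter); the two steps from compound 1, which carries methyl(propyl)amino at the same aromatic carbon, are equally within the scatter. No change at this position has yet moved the number beyond the scatter, so none beyond the scatter is expected from this step either. Compound 4 is therefore estimated at 300 nM, with a range from 120 nM to 800 nM, which corresponds to an expected step of a 1.1-fold higher number from compound 3 to compound 4 (0.03 log units; within the scatter).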

Compound 4, half-maximal inhibitory concentration: 167 nM
The estimate for compound 4 lay 1.8-fold (0.25 log units) above the measured number; the measured number falls inside the stated range.
By their numbers in this assay, from the lowest: compounds 4, 1, 3 and 2 (each within the scatter of the next).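

The bare piperidin-1-yl at this aromatic carbon stays within the scatter of all three earlier compounds in this assay, as shown by (a 1.7-fold lower number from compound 3 to compound 4 (0.22 log units; within the scatter)) , (a 1.8-fold lower number from compound 2 to compound 4 (0.24 log units; within the scatter)) and (a 1.3-fold lower number from compound 1 to compound 4 (0.12 log units; within the scatter)) . The piperidine ring here therefore needs neither the amino and methyl groups of compound 3 nor the methylamino group of compound 2 to keep its number within the scatter, and 0 hydrogen-bond donors in the entering group produce no step beyond it. No measurement available here accounts for this result.

Going by these compounds, whether a morpholin-4-yl ring, or a carboxylic acid on the piperidine ring, would move the number beyond the scatter remains open. The compounds shown also leave open how changes elsewhere on the shared core would read, since all four carry it unchanged.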